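Bromo to Chloro Repeated on a Second Core

A few compounds are considered here, and "the series" means these few. Any claim that something is new, unique, unknown or untested is made for them only; others in the source may bear on it.

Compound 1, `CN(C)c1ccc(C2CC(c3ccccc3)=NN2C2=NC(=O)/C(=C3\C(=O)Nc4ccc(Br)cc43)S2)cc1`: 270 nM
Compound 2, `CN(C)c1ccc(C2CC(c3ccccc3)=NN2C2=NC(=O)/C(=C3\C(=O)Nc4ccc(Cl)cc43)S2)cc1`: 250 nM
Compound 3, `COc1ccc(-c2cc(-c3ccc(Cl)cc3)n(C3C(=O)Nc4ccc(Br)cc43)n2)cc1`: 7650 nM

In a functional assay on cells (Cancer cell lines, Homo sapiens) for cytotoxicity, read by sulforhodamine B assay, with a stated time of 48 h (a lower number here means a stronger inhibitor of growth, a higher number a weaker inhibitor of growth), compound 1 gives 270 nM and compound 2 gives 250 nM. The change between them is chloro in place of bromo on an aromatic carbon and it made a step of a 1.1-fold lower number from compound 1 to compound 2 (0.03 log units; within the scatter). Compound 3 is built on a different core; the difference between the two cores is not broken down here. In this assay compound 3 gives 7650 nM, the highest of the three numbers. Compound 4, `COc1ccc(-c2cc(-c3ccc(Cl)cc3)n(C3C(=O)Nc4ccc(Cl)cc43)n2)cc1`, carries the same change, (chloro in place of bromo on an aromatic carbon), on that second core. Since the earlier step was a 1.1-fold lower number from compound 1 to compound 2 (0.03 log units; within the scatter), the step to compound 4 is expected to be small, about a 1.1-fold lower number from compound 3 to compound 4 (0.04 log units; within the scatter). Compound 4 is therefore estimated at 7000 nM, expected to lie between 3500 nM and 14000 nM.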

Compound 4, concentration for 50% growth inhibition: 6490 nM
For compound 4 the middle estimate is 1.1-fold (0.03 log units) above the measured one; measured number inside the range.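

In this assay, chloro in place of bromo on the second core gives a step of a 1.2-fold lower number from compound 3 to compound 4 (0.07 log units; within the scatter). The step on this core agrees with the one on the first core: the same change on two cores in this assay, a 1.1-fold lower number (0.03 log units; within the scatter) from compound 1 to compound 2 and a 1.2-fold lower number (0.07 log units; within the scatter) from compound 3 to compound 4, 1.1-fold (0.04 log units) apart, within the scatter of two such steps. This shows that, for these two pairs, a step that stays within the scatter on one core also does so on the other, but it does not show that a change with a larger step would carry over in the same way, nor that this one would on any further core.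

Only bromo and chloro appear at this aromatic carbon. From the compounds shown here alone, what an amine or a carboxylic acid there would do on either core, and whether its steps would match between the two cores, stays open.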